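Nitro for Hydroxy on a Shared Trimethoxyphenyl Enone Core

This account rests on a few compounds, and the source may have more. Where it says the series, first, only, none or still open, it means among the compounds named here.

Measured in a functional assay on HepG2 cells (Homo sapiens) for inhibition, read by MTT assay, with a stated time of 48 h; a higher number here means a weaker inhibitor, a lower number a stronger inhibitor:
compound 1 `COc1cc(C(=O)/C=C/c2ccc(O)cc2)cc(OC)c1OC` gives 16000 nM;
compound 2 `COc1cc(C(=O)/C=C/c2cc(O)ccc2O)cc(OC)c1OC` gives > 100000 nM, which is a limit of the assay rather than a number;
compound 3 `COc1cc(C(=O)/C=C/c2ccc([N+](=O)[O-])cc2)cc(OC)c1OC` gives > 100000 nM, also a limit of the assay.

The cores of compound 1 and compound 2 differ by 2,5-dihydroxyphenyl in place of 4-hydroxyphenyl on a double-bonded chain carbon bound to a double-bonded chain carbon, and the step of an at least 6.2-fold higher number from compound 1 to compound 2 (0.79 log units; beyond the scatter) is large. The change nitro in place of hydroxy on an aromatic carbon produces the step of an at least 6.2-fold higher number from compound 1 to compound 3 (0.79 log units; beyond the scatter), again large; both limits sit at the limit of > 100000 nM in this assay, at which 2 of the 3 values shown sit, so neither step can be sized beyond its lower bound.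

Compound 4 `COc1cc(C(=O)/C=C/c2cc([N+](=O)[O-])ccc2O)cc(OC)c1OC` awaits measurement in this assay. It differs from compound 2 by nitro in place of hydroxy on an aromatic carbon, the same kind of change as from compound 1 to compound 3, though here the place is meta to a large group and para to a hydroxy group, whereas in compound 3 it is para to a large group. Since compound 2 already gives only a limit, the expected step that the limit leaves unreadable from compound 2 to compound 4 cannot be resolved by the assay. Compound 4 is therefore expected to give about 150000 nM, most likely reported again as a limit, within 50000 nM to 500000 nM.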

Compound 4, half-maximal inhibitory concentration: > 100000 nM
Compound 4: no number, only a limit; the forecaster's own chance of this, stated with the estimate: 80%; the middle value lies beyond the limit too.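

In this assay compound 4 gives > 100000 nM, a limit of the assay and not a number. Going by these compounds alone, compound 2 also gives only a limit, so no step from it to compound 4 can be read: the limit of > 100000 nM in this assay, at which 3 of the 4 values shown sit. The compounds shown leave open how far compound 2, compound 3 and compound 4 actually lie beyond that limit.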